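The source may report more compounds than this note shows. Statements on the series, on what has been measured and on what is new or still open speak of the compounds shown alone.

Measured so far:
compound 1, `CCN(CC)c1ccc(NC(=O)c2c(-c3c(Cl)cccc3Cl)noc2C(C)C)cc1`: 861 nM in a functional assay on CHO-K cells with growth hormone secretagogue receptor type 1 (Homo sapiens) as the target, read by FLIPR; a lower number here means a stronger inhibitor, a higher number a weaker inhibitor
compound 2, `CCN(CC)c1ccc(NC(=O)c2c(-c3c(Cl)cccc3Cl)noc2CCC2OCCCO2)cc1`: 19 nM

Within the data shown here, compound 2 holds the lowest of the two numbers in this assay; its only neighbour, compound 1, stands a 45-fold lower number from compound 1 to compound 2 (1.66 log units; beyond the scatter) away. Compound 3, `CCN(CC)c1ccc(NC(=O)c2c(-c3c(Cl)cccc3Cl)noc2CCC2CCCO2)cc1`, differs from compound 2 by a group of 5 heavy atoms (4 carbon, 1 oxygen; one five-membered non-aromatic ring with 1 hetero atom) in place of a group of 6 heavy atoms (4 carbon, 2 oxygen; one six-membered non-aromatic ring with 2 hetero atoms), on a saturated chain carbon, two bonds along the chain from an aromatic carbon. Among the measured compounds shown here, the single measured step, a 45-fold lower number from compound 1 to compound 2 (1.66 log units; beyond the scatter), bears on this only loosely: it shows that the group at this end of the core can move the number a great deal, but there a group with no ring was replaced by the whole ring-bearing chain, whereas here one non-aromatic ring is exchanged for a related one. A modest step, if any, is expected, more likely upward. Compound 3 is expected near 40 nM, within 10 nM to 160 nM, which means a 2.1-fold higher number from compound 2 to compound 3 (0.32 log units; beyond the scatter).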

Compound 3, half-maximal inhibitory concentration: 57 nM
For compound 3 the middle estimate is 1.4-fold (0.15 log units) below the measured one; the range from low to high includes it.
By their numbers in this assay, from the lowest: compound 2; then compound 3; then compound 1.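

In this assay the exchange of the six-membered ring with two oxygens for oxolan-2-yl gives a 3.0-fold higher number from compound 2 to compound 3 (0.48 log units; beyond the scatter) on the chain, a modest step beyond the scatter. The oxolan-2-yl chain still retains a large step over isopropyl, a 15-fold lower number from compound 1 to compound 3 (1.18 log units; beyond the scatter) here, so a large gain does not depend on the six-membered ring. No measurement at hand accounts for the size of either step.

Open, going by these compounds, is whether any ring is needed, as a plain longer chain would show. Also open, on these data alone, is how a ring nitrogen, as in morpholine, would compare with oxolan-2-yl.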